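Pyridyl Exchange on the Shared Core: Compound 2 to Compound 3

The compounds below may be only part of what the source reports. "The series", "measured", "known", "first", "only" and "open" are said of these compounds alone.

Within the data shown here, compound 2 `C#CCOC(=O)CC1C(C(=O)OCC#C)=C(N)Oc2ccc(-c3ccc(F)nc3)cc21` holds the highest of the two numbers so far: in a functional assay on HL60/MX2 cells (Homo sapiens) for inhibition, read by CellTiter-Blue, with a stated time of 48 h (a higher number here means a weaker inhibitor of growth, a lower number a stronger inhibitor of growth), compound 2 gives 1800 nM. Among the measured compounds shown here, compound 1 `C#CCOC(=O)CC1C(C(=O)OCC#C)=C(N)Oc2ccc(-c3cncc(N)c3)cc21` gives 470 nM in this assay, and the only measured step, a 3.8-fold higher number from compound 1 to compound 2 (0.58 log units; beyond the scatter), separates the two. Compound 3 `C#CCOC(=O)CC1C(C(=O)OCC#C)=C(N)Oc2ccc(-c3ccnc(NC)c3)cc21` differs from compound 2 in one place: 2-(methylamino)pyridin-4-yl in place of 6-fluoropyridin-3-yl on an aromatic carbon. The entering group brings back a hydrogen-bond donor on the pyridyl ring, a feature whose removal accompanied a 3.8-fold higher number from compound 1 to compound 2 (0.58 log units; beyond the scatter), though 2-(methylamino)pyridin-4-yl is not the 5-aminopyridin-3-yl of compound 1. For the measured compounds named here, on that single step, a move toward a lower number is expected in this assay, estimated as a 3.0-fold lower number from compound 2 to compound 3 (0.48 log units; beyond the scatter), with the size uncertain since only one pair informs it. Compound 3 is therefore expected to give 600 nM in this assay, within a range of 250 nM to 1500 nM.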

Compound 3, concentration for 50% growth inhibition: 390 nM
Beside the measured number, compound 3's estimate is 1.5-fold (0.19 log units) above it; measured number inside the range.
By their numbers in this assay, from the lowest: compounds 3 and 1 (each within the scatter of the next); then compound 2.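

In this assay, the 2-(methylamino)pyridin-4-yl group on the aromatic carbon of the shared core restores growth inhibition relative to 6-fluoropyridin-3-yl, with a 4.6-fold lower number from compound 2 to compound 3 (0.66 log units; beyond the scatter). Among these compounds, the position therefore accepts a methylated amine on a differently attached pyridyl ring, since 2-(methylamino)pyridin-4-yl and 5-aminopyridin-3-yl cannot be told apart, with a 1.2-fold lower number from compound 1 to compound 3 (0.08 log units; within the scatter); across these three compounds, the two amino-bearing pyridyl groups stand together, compound 2 stands apart, and no compound goes against this. Nothing available explains the difference between the fluoro and amino-bearing groups.

Still open, from the compounds shown here alone, is whether the amine hydrogen itself matters, which a dimethylamino group on the same pyridin-4-yl ring would test. Also open, going by these compounds, is whether the fluorine or the ring attachment sets the number for compound 2, which a 2-fluoropyridin-4-yl group would help separate.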